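Replacing the 3-methoxybenzyl group of compound 3

The compounds below may be only part of what the source reports. "The series", "measured", "known", "first", "only" and "open" are said of these compounds alone.

Among the measured compounds shown here, in a functional assay on MDA-MB-231 cells (Homo sapiens) for inhibition, read by CCK-8 assay, with a stated time of 48 h (on this read-out higher numbers stand for weaker inhibition of growth and lower numbers for stronger inhibition of growth), compound 3 `COc1cccc(CNc2nc(Nc3ccc(N4CCN(C)CC4)cn3)ncc2Cl)c1` gives 20300 nM as the higher of the two true numbers so far. Compound 1 `Cc1ccccc1Nc1nc(Nc2ccc(N3CCNCC3)cn2)ncc1Cl` gives 5060 nM as the lower of them. Compound 2 `CN1CCN(c2ccc(Nc3ncc(Cl)c(NCc4ccc(F)cc4)n3)nc2)CC1` gives > 100000 nM in this assay and this value is a limit, not a number.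

Compound 4 `CC(C)c1cccc(Nc2nc(Nc3ccc(N4CCN(C)CC4)cn3)ncc2Cl)c1` carries one change from compound 3: 3-isopropylphenyl in place of 3-methoxybenzyl on a nitrogen on an aromatic ring with 3-isopropylphenyl in place of 3-methoxybenzyl on a nitrogen on an aromatic ring. For the measured compounds named here, the only measured step at this end of the molecule is an at least 4.9-fold lower number from compound 2 to compound 3 (0.69 log units; beyond the scatter) for 3-methoxyphenyl in place of 4-fluorophenyl, so a change here can move the number beyond the scatter. Compound 4 shares with compound 1 the lack of a saturated chain carbon on that nitrogen, and compound 1 gives 5060 nM despite other differences. A lower number is therefore expected, in a step beyond the scatter but not a large one. The expected change is a 3.4-fold lower number from compound 3 to compound 4 (0.53 log units; beyond the scatter) in this assay by this estimate. For compound 4 the estimated value is 6000 nM with an expected range of 1500 nM to 25000 nM in this read-out.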

Compound 4, concentration for 50% growth inhibition: 5590 nM
Compound 4: the middle estimate sits 1.1-fold (0.03 log units) above what was measured; the measured number falls inside the stated range.
By their numbers in this assay, from the lowest: compounds 1 and 4 (each within the scatter of the next); then compound 3. At a limit, above all of these: compound 2.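

In this assay, the swap gives a 3.6-fold lower number from compound 3 to compound 4 (0.56 log units; beyond the scatter). Among the compounds shown here, this is the first measured step at this position that alters the link to the nitrogen rather than only the groups on the ring: the saturated chain carbon of 3-methoxybenzyl is gone, and the ring is bound directly to the nitrogen. Measured against the 4-fluorobenzyl group, the change gives an at least 17-fold lower number from compound 2 to compound 4 (1.25 log units; beyond the scatter), a step whose size is only a bound: the limit of > 100000 nM in this assay, at which 1 of the 4 values shown sits.

Since the chain carbon and the methoxy group leave in a single step, the compounds shown do not say which of the two changes carries the shift. They also leave open how a 3-methoxyphenyl group on this nitrogen would read, or an amine or a carboxylic acid in place of the isopropyl group.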